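The source may hold more compounds than are shown below. What is called first, only, known or untested is meant among the compounds shown, and "the series" means these compounds.

Of the compounds shown here, three sharing one core have been tested in a functional assay on MIA PaCa-2 cells (Homo sapiens) for inhibition, read by MTT assay, with a stated time of 48 h, tested at 10 uM; on this read-out lower numbers stand for less inhibition of growth and higher numbers for more inhibition of growth at the one concentration tested. Compound 1 (`Cc1cc(=O)c2c(O)cc(OC/C=C/c3ccccc3)c([C@H]3CCN(C)C[C@H]3O)c2o1`) gives 11%, compound 2 (`CCN(CC)Cc1c(O)c([C@H]2CCN(C)C[C@H]2O)c2oc(C)cc(=O)c2c1O`) gives 27% and compound 3 (`Cc1cc(=O)c2c(O)c(CN3CCC(c4ccccc4)CC3)c(O)c([C@H]3CCN(C)C[C@H]3O)c2o1`) gives 16%. Compound 3 thus stands within the scatter of compound 1, and the gap up to compound 2 lies beyond the scatter.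

Compound 4 (`Cc1cc(=O)c2c(O)c(CN3CCCCC3)c(O)c([C@H]3CCN(C)C[C@H]3O)c2o1`) is compound 3 with one change: hydrogen in place of phenyl on a saturated ring carbon. Going by the values given here, no measured pair isolates this change, so the step has no direct precedent. Among the compounds with values here, the only guide is indirect: compound 2, which carries no phenyl, gives 27%, whereas compound 1 and compound 3 both carry one. A small rise in this assay is therefore expected, one that stays within the scatter, and the estimated step is a number 5 percentage points higher from compound 3 to compound 4 (within the scatter). For compound 4 the expected value is 21%, with an estimated range of 8% to 36%.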

Compound 4, percent growth inhibition at one concentration: 14%
Compound 4: middle estimate off by 7 percentage points, on the high side, and the stated range covers the measured number.
By their numbers in this assay, from the lowest: compounds 1, 4 and 3 (each within the scatter of the next); then compound 2.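

In this assay the exchange of phenyl for hydrogen on the saturated ring carbon gives a number 2 percentage points lower from compound 3 to compound 4 (within the scatter) and so leaves the read-out unmoved, which shows that this assay cannot tell the two groups apart at this position. The exchange of diethylamino for piperidin-1-yl on the saturated chain carbon gives a number 13 percentage points lower from compound 2 to compound 4 (beyond the scatter) as a modest step, and of the two one-place steps it is the only one beyond the scatter. Nothing at hand accounts for either step.

From the compounds shown here alone, whether a hydroxyl or a carboxylic acid on that saturated ring carbon would shift the number remains open. So does whether dimethylamino on the chain carbon would fall nearer compound 2 or compound 4.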